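Bromo for fluoro on the aryl ring of compound 1

The compounds below may be only part of what the source reports. "The series", "measured", "known", "first", "only" and "open" are said of these compounds alone.

Compound 1 `Cn1c(=O)c(=O)n(C2CCCC2)c2nc(N/N=C/c3ccc(O)c(F)c3)ncc21`: 85200 nM in a functional assay on PC-3 cells (Homo sapiens) for antiproliferative activity, read by MTT assay; a lower number here means a stronger inhibitor, a higher number a weaker inhibitor
Compound 2 `COc1cccc(/C=N/Nc2ncc3c(n2)n(C2CCCC2)c(=O)c(=O)n3C)c1`: 20700 nM
Compound 3 `Cc1cc(C)c(/C=N/Nc2ncc3c(n2)n(C2CCCC2)c(=O)c(=O)n3C)c(C)c1`: 13900 nM

Compound 1 stands highest of the three numbers in this assay, so it is the weakest inhibitor of this set. Compound 4 `Cn1c(=O)c(=O)n(C2CCCC2)c2nc(N/N=C/c3ccc(O)c(Br)c3)ncc21` differs from it by bromo in place of fluoro on an aromatic carbon. Going by the values given here, no measured step changes only this substituent; the steps of a 4.1-fold lower number from compound 1 to compound 2 (0.61 log units; beyond the scatter) and a 6.1-fold lower number from compound 1 to compound 3 (0.79 log units; beyond the scatter) exchange the whole aryl group, so they bear on compound 4 only loosely, showing that the number moves modestly when the hydroxyphenyl ring is altered. A single halogen exchange is expected to move the number less, a step of a 1.4-fold lower number from compound 1 to compound 4 (0.15 log units; within the scatter) or none beyond the scatter. Compound 4 is therefore estimated at 60000 nM, within 25000 nM to 150000 nM.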

Compound 4, half-maximal inhibitory concentration: 11600 nM
Beside the measured number, compound 4's estimate is 5.2-fold (0.71 log units) above it; the measured number lies below the stated range.
By their numbers in this assay, from the lowest: compounds 4, 3 and 2 (each within the scatter of the next); then compound 1.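

In this assay the exchange of one halogen ortho to a hydroxy group is enough by itself to give a 7.3-fold lower number from compound 1 to compound 4 (0.87 log units; beyond the scatter) with the rest of the molecule unchanged. The aryl groups without a hydroxy group give a 1.2-fold lower number from compound 3 to compound 4 (0.08 log units; within the scatter) and a 1.8-fold lower number from compound 2 to compound 4 (0.25 log units; within the scatter) within the scatter, so among these compounds the high number of compound 1 goes with the 3-fluoro-4-hydroxyphenyl group and not with a hydroxyphenyl ring as such. Nothing measured here explains the change.

Going by these compounds, whether chloro or iodo at this place would fall with bromo or with fluoro remains open. So does whether the bromo step would hold with a methoxy group in place of the hydroxy group.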